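The compounds below may be only part of what the source reports. "The series", "measured", "known", "first", "only" and "open" are said of these compounds alone.

Measured so far:
- compound 1, `COc1cc(Cl)cc(/C=C/C(=O)c2ccc(Br)cc2)c1O`: 38.2%
- compound 2, `O=C(/C=C/c1cc(Br)ccc1O)c1ccc(Br)cc1`: 28.7%
- compound 3, `COC(=O)C1=C(N)Oc2c(OC)cc(Br)cc2C1CC(=O)c1ccc(Cl)cc1`: 80.3%

These three compounds were tested in a functional assay on MCF7 cells (Homo sapiens) for antiproliferative activity, read by sulforhodamine B assay, with a stated time of 72 h, tested at 10 uM; a lower number here means a stronger effect, a higher number a weaker effect of the compound at the concentration tested. Compound 3 gives the highest of the three numbers, so its effect on cell growth at this concentration is the weakest; its nearest neighbour is compound 1, whose number is lower by a margin beyond the usual scatter, and compound 2 lies further away still. Compound 3 also differs from the other two in its whole core, so nothing in the numbers separates the part played by the core from the part played by the rest of the molecule.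

The next compound, compound 4, `COC(=O)C1=C(N)Oc2c(OC)cc(Br)cc2C1CC(=O)c1ccc(Br)cc1`, keeps the core of compound 3 and changes only one thing: bromo in place of chloro on an aromatic carbon. Among the compounds with values here, no measured pair in this set shows the effect of exchanging chloro for bromo on an aromatic carbon alone. With only one heavy atom exchanged for another of the same kind, a step from compound 3 to compound 4 of a number 4.3 percentage points lower from compound 3 to compound 4 (within the scatter) in this assay is expected, which stays within the scatter. Compound 4 is therefore estimated at 76%, with a range from 58% to 92%.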

Compound 4, a percentage reported as activity, at one concentration (the size of the read-out at that concentration, not a potency): 50.2%
Compound 4: middle estimate off by 25.8 percentage points, on the high side; measured number below the stated range.
By their numbers in this assay, from the lowest: compounds 2 and 1 (each within the scatter of the next); then compound 4; then compound 3.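

In this assay, replacing 4-chlorophenyl with 4-bromophenyl gives a number 30.1 percentage points lower from compound 3 to compound 4 (beyond the scatter), a large step. Within the data shown here, this is the first pair here that differs in one place, so it gives the first direct reading of this position: on the core shared by compound 3 and compound 4, exchanging one halogen for another at the site para to a large group is enough to strengthen the effect on cell growth at the concentration tested. Nothing available explains why this single exchange has so large an effect.

The compounds shown do not tell how fluoro, methyl, methoxy or an amine at this position would compare with chloro and bromo. They also leave open whether the same exchange would produce a similar step on the core of compound 1 or compound 2.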